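The source may hold more compounds than are shown below. What is called first, only, known or untested is meant among the compounds shown, and "the series" means these compounds.

Compound 1 `CS(=O)(=O)c1ccc(C(=O)NCCC(=O)N2CCCCC2)cc1[N+](=O)[O-]` was tested in an assay on isolated protein for inhibition of thyroid hormone receptor alpha (Homo sapiens), read by fluorescence polarization; a higher number here means a weaker inhibitor, a lower number a stronger inhibitor. In this assay compound 1 gives > 60000 nM, which is a limit of the assay and not a number. Compound 2 `CS(=O)(=O)c1ccc(C(=O)NCCC(=O)N2CCCc3ccccc32)cc1[N+](=O)[O-]` differs from it by 1,2,3,4-tetrahydroquinolin-1-yl in place of piperidin-1-yl on a carbonyl carbon. In this assay compound 2 gives > 60000 nM, again a limit. The step that the two limits leave unreadable from compound 1 to compound 2 is therefore unreadable. Compound 3 `CN(Cc1ccccc1F)C(=O)CNC(=O)c1ccc(S(C)(=O)=O)c([N+](=O)[O-])c1` completes the measured set. In this assay compound 3 gives > 60000 nM, likewise a limit. Compound 1 thus stands at the limit of > 60000 nM in this assay, at which 3 of the 3 values shown sit, and no measured number places it anywhere else.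

Compound 4 `CS(=O)(=O)c1ccc(C(=O)NCCCC(=O)N2CCCCC2)cc1[N+](=O)[O-]` has not yet been measured. It differs from compound 1 in one place: ((piperidin-1-yl)carbonyl)methyl in place of (piperidin-1-yl)carbonyl on a saturated chain carbon, two bonds along the chain from an amide-type nitrogen. Among the compounds with values here, the only measured step touching this end of the molecule is a step that the two limits leave unreadable from compound 1 to compound 2, and its size cannot be read because the limit of > 60000 nM in this assay, at which 3 of the 3 values shown sit, is where both of its compounds sit. Within the data shown here, with every known value a limit, there is no measured step that would point either way. Compound 4 is therefore expected to stay at that limit, with an estimated value of 100000 nM and a range from 30000 nM to 400000 nM. The step that the limit leaves unreadable from compound 1 to compound 4 is expected to show no change beyond the scatter.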

Compound 4, half-maximal inhibitory concentration: > 60000 nM
Compound 4: no number, only a limit (the forecaster's own chance of this, stated with the estimate: 85%); the middle value lies beyond the limit too.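

Within the data shown here, compound 1 and compound 4 both stand at a limit of the assay and not at a number, so no step between them can be read. The whole set sits at one place: the limit of > 60000 nM in this assay, at which 4 of the 4 values shown sit.

The compounds shown leave open which structural change, if any, would bring a compound to a measured number in this assay.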